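The source may report more compounds than this note shows. Statements on the series, on what has been measured and on what is new or still open speak of the compounds shown alone.

Compound 1 `COc1ccc(-c2c(C#N)c(-c3ccc(Cl)cc3)nc3c2c(-c2cccnc2)nn3-c2ccccc2)cc1` and compound 2 `COc1ccc(-c2c(C#N)c(-c3ccc(C)cc3)nc3c2c(-c2cccnc2)nn3-c2ccccc2)cc1` share one core and differ only at a single aromatic carbon. In a functional assay on HepG2 cells (Homo sapiens) for cytotoxicity, read by colorimetric assay (on this read-out higher numbers stand for weaker inhibition and lower numbers for stronger inhibition), compound 1 gives 4 ug/mL, and in this assay compound 2 gives 4.34 ug/mL. Among the compounds with values here, the step of a 1.1-fold higher number from compound 1 to compound 2 (0.04 log units; within the scatter) is the only measured step in the set. On the two numbers shown, compound 2 stands at the higher of the two, with compound 1 as its nearest neighbour, the gap being within the scatter, so no order between them is claimed.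

Compound 3 `COc1ccc(-c2c(C#N)c(-c3ccc(F)cc3)nc3c2c(-c2cccnc2)nn3-c2ccccc2)cc1` has not yet been measured in this assay. Compound 3 differs from compound 2 by fluoro in place of methyl on an aromatic carbon. Within the data shown here, the one measured step that bears on this position, the exchange of chloro for methyl, stayed within the scatter, so a second small substituent at the same place is expected to leave the number much where compound 2 stands, with no direction beyond the scatter. The step from compound 2 to compound 3 is therefore estimated as a 1.0-fold higher number from compound 2 to compound 3 (0.02 log units; within the scatter). Compound 3 is expected in this assay at about 4.5 ug/mL, in a range from 2.2 ug/mL to 9 ug/mL.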

Compound 3, half-maximal inhibitory concentration: 3.43 ug/mL
The estimate for compound 3 lay 1.3-fold (0.12 log units) above the measured number, within the range that was stated.
By their numbers in this assay, from the lowest: compounds 3, 1 and 2 (each within the scatter of the next).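

In this assay, the step of a 1.3-fold lower number from compound 2 to compound 3 (0.10 log units; within the scatter) and the step of a 1.2-fold lower number from compound 1 to compound 3 (0.07 log units; within the scatter) both stay within the scatter, so this position para to a large group now has three substituents on the same aromatic carbon with nothing to separate them. The earlier pair showed only that chloro and methyl could not be told apart here; fluoro now extends that to a third small substituent, and no order among compound 1, compound 2 and compound 3 is claimed. No available evidence bears on why the read-out stays level across these exchanges.

The compounds shown carry only chloro, methyl or fluoro at this place, so it remains open whether a larger or differently functionalised group, such as an amine, a carboxylic acid or a longer alkyl chain, would move the number beyond the scatter. They also vary only this one place on the shared core, leaving open how the number responds to changes elsewhere, for example to replacing the nitrile or the methoxy group.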